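This account rests on a few compounds, and the source may have more. Where it says the series, first, only, none or still open, it means among the compounds named here.

In an ADME assay on 184B5 cells (Homo sapiens) for cytotoxicity, read by MTT assay, with a stated time of 72 h (on this read-out higher numbers stand for weaker inhibition of growth and lower numbers for stronger inhibition of growth), three compounds have been measured so far. Compound 1 `N#C[Se]c1ccc(NC(=O)OCc2ccc([N+](=O)[O-])cc2)cc1` gives 6000 nM. Compound 2 `N#C[Se]c1ccc(NC(=O)OCc2ccccc2)cc1` gives 5000 nM, and compound 3 `C=CCOC(=O)Nc1ccc([Se][Se]c2ccc(NC(=O)OCC=C)cc2)cc1` gives 6400 nM. Among the compounds with values here, the one step between compounds that differ in a single place is a 1.2-fold lower number from compound 1 to compound 2 (0.08 log units; within the scatter), hydrogen in place of nitro on an aromatic carbon. Compound 2 has the lowest of the three numbers shown, yet both compound 1 and compound 3 lie within the scatter of it, so nothing separates the three.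

Compound 4 `CCCCCCOC(=O)Nc1ccc([Se]C#N)cc1` has not yet been measured. It differs from compound 2 by pentyl in place of phenyl on a saturated chain carbon bound to an oxygen next to a carbonyl group. Within the data shown here, no measured step touches this part of the structure: the only step, from compound 1 to compound 2, alters a substituent on the aromatic ring, and all three numbers sit within the scatter of one another. Nothing in the data therefore points to a shift beyond the scatter in either direction. For compound 4 the expected step is no change at the digits printed from compound 2 to compound 4 (within the scatter). Compound 4 is estimated at 5000 nM, within a range from 2500 nM to 10000 nM.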

Compound 4, concentration for 50% growth inhibition: 4600 nM
Beside the measured number, compound 4's estimate is 1.1-fold (0.04 log units) above it, and the stated range covers the measured number.
By their numbers in this assay, from the lowest: compounds 4, 2, 1 and 3 (each within the scatter of the next).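

In this assay, pentyl in place of phenyl on a saturated chain carbon bound to an oxygen next to a carbonyl group gives a 1.1-fold lower number from compound 2 to compound 4 (0.04 log units; within the scatter). Within the data shown here, this is the first look at this position, as the earlier step touched only a substituent on the aromatic ring, and it shows that an open chain without a ring reads the same as phenyl here. Nothing measured alongside these numbers bears on why the two groups read alike.

From the compounds shown here alone, it remains open whether an amine or a carboxylic acid at the end of the chain, or a much shorter chain such as methyl, would move the number beyond the scatter. Going by these compounds, it is also open which part of the structure, if any, this read-out responds to, since each number so far lies within the scatter of the next.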